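Replacing phenyl with 1,3-thiazol-2-yl in compound 1

This account rests on a few compounds, and the source may have more. Where it says the series, first, only, none or still open, it means among the compounds named here.

Compound 1 `CN1C(=O)C2=C(C1=O)N(CC(=O)Nc1ccc(-c3ccccc3)cc1)CCC2` (22 mL.min-1.g-1)
Compound 2 `CN1C(=O)C2=C(C1=O)N(CC(=O)Nc1ccc(-c3ccccc3)cn1)CCC2` (175 mL.min-1.g-1)
Compound 3 `CN1C(=O)C2=C(C1=O)N(CC(=O)Nc1ccc(-c3ccccc3)nc1)CCC2` (7 mL.min-1.g-1)

In an ADME assay on microsomes from liver (Homo sapiens) for metabolic stability (a lower number here means slower removal, a higher number faster removal of the compound), compound 1 (22 mL.min-1.g-1) is the second highest of three numbers. Compound 3 (7 mL.min-1.g-1) lies lower and compound 2 (175 mL.min-1.g-1) lies higher, and both gaps from compound 1 are beyond the usual scatter between repeated measurements.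

The next compound to be tested is compound 4 `CN1C(=O)C2=C(C1=O)N(CC(=O)Nc1ccc(-c3nccs3)cc1)CCC2`. It keeps the core of compound 1 and changes a single group: 1,3-thiazol-2-yl in place of phenyl on an aromatic carbon. This carbon belongs to a six-membered aromatic ring of carbon only, and the new group stands para to a large group.

Going by the values given here, none of the measured compounds carries 1,3-thiazol-2-yl, so the data show no direction for this change. The distance between compound 3 (7 mL.min-1.g-1) and compound 2 (175 mL.min-1.g-1) shows that numbers in this small set can lie far apart, so the range around the estimate should stay wide. No change beyond the scatter is expected in this assay (estimated step a 1.1-fold lower number from compound 1 to compound 4 (0.04 log units; within the scatter)). Compound 4 is expected at 20 mL.min-1.g-1 (estimated range 7 mL.min-1.g-1 to 60 mL.min-1.g-1).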

Compound 4, intrinsic clearance in microsomes: 24 mL.min-1.g-1
The estimate for compound 4 lay 1.2-fold (0.08 log units) below the measured number; low and high end bracket the measured number.
By their numbers in this assay, from the lowest: compound 3; then compounds 1 and 4 (each within the scatter of the next); then compound 2.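

Putting 1,3-thiazol-2-yl in place of phenyl gives a 1.1-fold higher number from compound 1 to compound 4 (0.04 log units; within the scatter) in this assay, so this place on the ring, para to a large group, accepts this exchange with no change that stands out from repeat measurements. The exchange is not a trivial one on paper: a six-membered aromatic ring of carbon only leaves, a five-membered aromatic ring with 2 hetero atoms enters, and the count of hydrogen-bond acceptors goes from 0 to 2, yet the clearance reading stays within the scatter. No measurement available here explains why the reading holds steady.

This is a single step at one place, so it cannot show whether other groups, such as a morpholine ring or a carboxylic acid, would be accepted there as well. It also leaves open whether the same exchange would stay as quiet on the ring forms of compound 2, at 175 mL.min-1.g-1, and compound 3, at 7 mL.min-1.g-1.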